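A fluorine-bearing ring swapped in for a chlorine-bearing ring

The source may hold more compounds than are shown below. What is called first, only, known or untested is meant among the compounds shown, and "the series" means these compounds.

Compound 1 `COc1ccccc1/C=C/C(=O)OC/C=C/c1cc(OC)c(OC)cc1OC` gives 101 umol/kg
Compound 2 `COc1cc(OC)c(OC)cc1/C=C/COC(=O)/C=C/c1cccc(Br)c1` gives 175 umol/kg
Compound 3 `COc1cc(OC)c(OC)cc1/C=C/COC(=O)/C=C/c1ccccc1Cl` gives 151 umol/kg

All three values come from a functional assay on the whole organism (strain Kunming) with Mus musculus as the target, with a stated time of 0.5 h (on this read-out higher numbers stand for an effect only at larger amounts of compound and lower numbers for an effect already at smaller amounts), and lie close together. Compound 3 (151 umol/kg) does not stand apart from the other two, as each comparison with it falls within the normal scatter of repeated measurements. The nearest comparison is a 1.2-fold lower number from compound 2 to compound 3 (0.06 log units; within the scatter) and the other is a 1.5-fold higher number from compound 1 to compound 3 (0.17 log units; within the scatter) in the same read-out.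

The next compound is compound 4 `COc1cc(OC)c(OC)cc1/C=C/COC(=O)/C=C/c1ccc(F)cc1` and the change leading to it is 4-fluorophenyl in place of 2-chlorophenyl on a double-bonded chain carbon bound to a double-bonded chain carbon with the rest of the structure left as it is. Among the measured compounds shown here, no compound measured so far carries the 4-fluorophenyl group, so there is no direct precedent for it. The closest guide is the exchange of one aryl group for another at this same place. That exchange has been made three times, giving a 1.2-fold lower number from compound 2 to compound 3 (0.06 log units; within the scatter) as well as a 1.7-fold higher number from compound 1 to compound 2 (0.24 log units; within the scatter) and a 1.5-fold higher number from compound 1 to compound 3 (0.17 log units; within the scatter) and none of these exceeds the scatter.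

The same is therefore expected here, with no step beyond the scatter in this assay and no firm direction. The expected step is a 1.1-fold lower number from compound 3 to compound 4 (0.05 log units; within the scatter) on this basis. For compound 4 the estimated value is 135 umol/kg with an expected range from 65 umol/kg to 280 umol/kg in this read-out.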

Compound 4, dose for half-maximal effect: 92.9 umol/kg
For compound 4 the middle estimate is 1.5-fold (0.16 log units) above the measured one; the range from low to high includes it.
By their numbers in this assay, from the lowest: compounds 4, 1, 3 and 2 (each within the scatter of the next).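

In this assay, the 4-fluorophenyl group stays within the scatter of each of the three aryl groups placed here before it: 2-chlorophenyl (a 1.6-fold lower number from compound 3 to compound 4 (0.21 log units; within the scatter)), 3-bromophenyl (a 1.9-fold lower number from compound 2 to compound 4 (0.28 log units; within the scatter)) and 2-methoxyphenyl (a 1.1-fold lower number from compound 1 to compound 4 (0.04 log units; within the scatter)). The earlier compounds had already shown this for chlorine, bromine and methoxy, and a fluorine-bearing ring now extends the same picture, so all four aryl groups at this place on a double-bonded chain carbon bound to a double-bonded chain carbon give numbers that cannot be told apart, with no compound among them going against this. Nothing available shows what lies behind this closeness or links these numbers to any measured property of the groups.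

All four rings shown carry one substituent or, in the case of the shared core, stay unchanged, so it remains open whether an unsubstituted phenyl ring, an amine or a carboxylic acid at this place would also stay within the scatter. As far as these compounds go, it is equally open whether the same closeness would hold if an amide took the place of the ester in the linking chain.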